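This account rests on a few compounds, and the source may have more. Where it says the series, first, only, none or still open, it means among the compounds named here.

Measured so far:
Compound 1 `COc1cc(Cl)cc2nc(N3CCN(C)CC3)oc12`, which gives 0.62 in an assay on ileum (strain Hartley) with 5-hydroxytryptamine receptor 3A (Cavia porcellus) as the target; on this read-out higher numbers stand for larger maximal responses and lower numbers for smaller maximal responses.
Compound 2 `Cc1cc(Cl)cc2nc(N3CCN(C)CC3)oc12`, which gives 0.24 in this assay.
Compound 3 `CN1CCN(c2nc3cccc(Cl)c3o2)CC1`, which gives 0.24 in this assay.

Compound 3 sits level with compound 2 at the digits shown, and together the two hold the lowest numbers of the three. Among the measured compounds shown here, compound 1 stands apart: the only measured step is a number 0.38 lower from compound 1 to compound 2 (beyond the scatter), a change from methoxy to methyl that is well beyond the scatter. Compound 2 and compound 3 differ by methyl against hydrogen, and their values are indistinguishable.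

Compound 4 `CN1CCN(c2nc3cc(Cl)cc(Cl)c3o2)CC1` arises from compound 3 by chloro in place of hydrogen on an aromatic carbon. For the measured compounds named here, no measured step involves chloro entering in place of hydrogen, so the step from compound 1 to compound 2 bears on it only loosely, as a sign that this position can move the number strongly. Since the values of compound 2 and compound 3 give no sign that a small group there shifts the number, the expected step is a number 0.060 higher from compound 3 to compound 4 (within the scatter), with a wide range. Compound 4 is estimated at 0.3, between 0.15 and 0.55.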

Compound 4, intrinsic activity: the largest response reached, as a fraction of the reference agonist's: 0.14
For compound 4 the middle estimate is 0.16 above the measured one; measured number outside the range, below it.
By their numbers in this assay, from the lowest: compounds 4, 2 and 3 (each within the scatter of the next); then compound 1.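

In this assay, the first chloro in place of hydrogen on this carbon, meta to a chloro group and para to a fused ring, gives a number 0.10 lower from compound 3 to compound 4 (within the scatter), so this change shows no shift beyond the scatter. At the carbon that carries methyl in compound 2, chloro in place of methyl gives a number 0.10 lower from compound 2 to compound 4 (within the scatter), whereas chloro in place of methoxy gives a number 0.48 lower from compound 1 to compound 4 (beyond the scatter), which sets methoxy apart from both methyl and chloro at that carbon. Nothing measured here accounts for these steps.

As far as these compounds go, it remains open whether an ethoxy group or an amine at the methoxy-bearing carbon would match the number of compound 1. From the compounds shown here alone, it also remains open whether a nitrile in place of the new chloro would stay within the scatter of compound 3.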